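The compounds below may be only part of what the source reports. "The series", "measured", "known", "first", "only" and "open" are said of these compounds alone.

Compound 1 `COC(=O)C(=O)/C=C(\O)c1ccccc1Cl`: 31%
Compound 2 `COC(=O)C(=O)/C=C(\O)c1ccccc1[N+](=O)[O-]`: 1%

Compound 1 stands highest of the two numbers in an assay for inhibition of kynurenine 3-monooxygenase (Rattus norvegicus), tested at 10 uM; a lower number here means less inhibition, a higher number more inhibition at the concentration tested (going by the name of the read-out); compound 2 is the nearest, with a number 30 percentage points lower from compound 1 to compound 2 (beyond the scatter). Compound 3 `COC(=O)C(=O)/C=C(\O)c1cccc(Cl)c1Cl` differs from compound 1 by chloro in place of hydrogen on an aromatic carbon. Within the data shown here, no measured step bears directly on this change: the step from compound 1 to compound 2 alters the group already present rather than the hydrogen that here gives way to chloro. The expectation in this assay is therefore a step of no more than the scatter in either direction, namely a number 4 percentage points higher from compound 1 to compound 3 (within the scatter). Compound 3 is estimated at 35%, between 15% and 55%.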

Compound 3, a percentage reported as inhibition, at one concentration (the size of the read-out at that concentration, not a potency): 14%
For compound 3 the middle estimate is 21 percentage points above the measured one, outside the stated range (below it).
By their numbers in this assay, from the lowest: compound 2; then compound 3; then compound 1.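

Chloro in place of hydrogen, ortho to a chloro group, gives a number 17 percentage points lower from compound 1 to compound 3 (beyond the scatter) in this assay at this position, the first change shown there. This aromatic carbon is therefore not indifferent to substitution, and a second chloro does not add inhibition. Nothing available accounts for this step.

From the compounds shown here alone, whether fluoro, methoxy or an amine at this position would also lower the number remains open. So does whether chloro here would have the same effect without the first chloro group.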